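Swapping a naphthyl for a chloroindolyl on a shared core

A few compounds are considered here, and "the series" means these few. Any claim that something is new, unique, unknown or untested is made for them only; others in the source may bear on it.

Measured so far:
compound 1, `NC(=O)c1ccc2c(c1)CCOC2CCN1CC=C(c2cccc3ccccc23)CC1`, 153 nM
compound 2, `C[C@H]1CC(c2c[nH]c3cc(F)ccc23)CCN1CCC1OCCc2cc(C(N)=O)ccc21`, > 1000 nM
compound 3, `NC(=O)c1ccc2c(c1)CCOC2CCN1CC=C(c2c[nH]c3c(Cl)c(Cl)ccc23)CC1`, > 1000 nM

These three compounds were tested in an assay on cells for binding affinity to 5-hydroxytryptamine receptor 1B (Homo sapiens), read by radioligand binding; a higher number here means a weaker inhibitor, a lower number a stronger inhibitor. Going by the values given here, compound 1 gives 153 nM, and it is the only compound here with an actual number. For compound 2 the assay reports only a limit, > 1000 nM. For compound 3 the result is likewise a limit, > 1000 nM, so no number is known for it either. Compound 1 therefore stands alone as the measurable point among the three, while the other two sit at the limit of > 1000 nM in this assay, at which 2 of the 3 values shown sit.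

The unmeasured compound 4, `NC(=O)c1ccc2c(c1)CCOC2CCN1CC=C(c2c[nH]c3cc(Cl)ccc23)CC1`, keeps the core of compound 1 and changes only the aromatic group hanging from the ring: 6-chloro-1H-indol-3-yl in place of naphthalen-1-yl on a double-bonded ring carbon. Compound 3 carries a closely related chlorinated indolyl group on the same core and reaches only a limit, which suggests that this kind of swap tends to cost affinity. A step from compound 1 toward weaker binding is therefore expected, probably beyond the usual scatter, as a 3.9-fold higher number from compound 1 to compound 4 (0.59 log units; beyond the scatter). Compound 4 is estimated at 600 nM, with a plausible range from 150 nM to 3000 nM, and a fair chance that the assay again reports only a limit.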

Compound 4, inhibition constant: > 1000 nM
Compound 4: no number, only a limit; the forecaster's own chance of this, stated with the estimate: 40%; at least 1.6-fold (0.22 log units) between middle value and limit.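

In this assay, putting 6-chloro-1H-indol-3-yl in place of naphthalen-1-yl on the double-bonded ring carbon, with the rest of the shared core unchanged, gives an at least 6.5-fold higher number from compound 1 to compound 4 (0.81 log units; beyond the scatter). Going by these compounds alone, this is the first comparison here between compounds that differ in only one place, and it shows directly that this swap weakens binding beyond the usual scatter, although the value for compound 4 is a limit and not a number, so the full size of the step remains unknown. Compound 3 and compound 4 differ by hydrogen in place of chloro on an aromatic carbon, but both give only limits, so that step cannot be read, and the compounds now crowd at one ceiling: the limit of > 1000 nM in this assay, at which 3 of the 4 values shown sit.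

Still open, on these data alone, is whether the loss follows the chloro group or the indolyl group itself, a question that a plain 1H-indol-3-yl group on this core would help to settle. Also open, as far as these compounds go, is whether a methoxy group on the naphthalen-1-yl ring would keep, strengthen or weaken the binding seen for compound 1.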